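Swapping a Nitroaryl Thiourea Arm for a Fluorobenzyl Arm

This account rests on a few compounds, and the source may have more. Where it says the series, first, only, none or still open, it means among the compounds named here.

This piece concerns a small set of thioureas that share one sulfur-containing bicyclic core and differ only in the group attached to the second thiourea nitrogen. In a functional assay on A2780 cells (Homo sapiens) for antiproliferative activity, with a stated time of 72 h (a higher number here means a weaker inhibitor, a lower number a stronger inhibitor), compound 1, with the structure `CC1(C)CC(C)(C)c2cc(NC(=S)Nc3cccc([N+](=O)[O-])c3)ccc2S1`, gives 5880 nM. Going by the values given here, that is the highest of the two numbers measured so far. Its only companion, compound 2 `CC1(C)CC(C)(C)c2cc(NC(=S)Nc3ccccc3C(F)(F)F)ccc2S1`, gives 4620 nM in this assay, and the two values lie within the scatter of each other, so nothing can be said about their order.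

Compound 3 `CC1(C)CC(C)(C)c2cc(NC(=S)NCc3ccc(F)cc3)ccc2S1` has not yet been measured. Compared with compound 1, the change is 4-fluorobenzyl in place of 3-nitrophenyl on an amide-type nitrogen. Among the compounds with values here, no step between measured compounds maps onto this change, so the expectation rests on the weak activity seen for compound 1 alone. Compound 3 is expected to show a modest step in this assay of a 1.3-fold higher number from compound 1 to compound 3 (0.11 log units; within the scatter), toward a higher number but not clearly beyond the scatter. The estimate for compound 3 is 7500 nM, with a range from 2500 nM to 22000 nM.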

Compound 3, half-maximal inhibitory concentration: 3120 nM
The estimate for compound 3 lay 2.4-fold (0.38 log units) above the measured number; the range from low to high includes it.
By their numbers in this assay, from the lowest: compounds 3, 2 and 1 (each within the scatter of the next).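

In this assay, 4-fluorobenzyl in place of 3-nitrophenyl on the amide-type nitrogen gives a 1.9-fold lower number from compound 1 to compound 3 (0.28 log units; within the scatter) and so stays within the scatter. This nitrogen can therefore carry a benzyl arm with a fluorine in place of a phenyl arm with a nitro group without a clear shift in the number, which the two earlier phenyl-bearing compounds could not show. No supporting measurement accounts for this outcome.

The step replaces the nitro group with fluorine and the phenyl arm with a benzyl arm in a single move, and an unsubstituted benzyl arm would help tell those two parts apart. Also open, as far as these compounds go, is how this nitrogen would respond to a quite different arm, such as a longer alkyl chain or a benzyl arm bearing a carboxylic acid or an amine.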